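A few compounds are considered here, and "the series" means these few. Any claim that something is new, unique, unknown or untested is made for them only; others in the source may bear on it.

Compound 1 `CC1=C(N2CC2)C(=O)C(CC(C)OC(N)=O)=C(N2CC2)C1=O` is the stronger of the two measured compounds in a functional assay on L1210 cells (Mus musculus), with a stated time of 1 days; on this read-out lower numbers stand for lower potency and higher numbers for higher potency (the scale is a negative logarithm): compound 1 gives 5.86, while compound 2 `CC1=C(N2CC2)C(=O)C(Cc2ccccc2)=C(N2CC2)C1=O` gives 4.74. For the measured compounds named here, the only measured step, a number 1.12 log units lower from compound 1 to compound 2 (beyond the scatter), shows that replacing the carbamate-bearing chain of compound 1 costs much potency. Compound 3 `COCCC1=C(N2CC2)C(=O)C(C)=C(N2CC2)C1=O` differs from compound 1 by a group of 3 heavy atoms (2 carbon, 1 oxygen; no ring) in place of a group of 6 heavy atoms (3 carbon, 1 nitrogen, 2 oxygen; no ring), on a saturated chain carbon bound to a double-bonded ring carbon. Since the same chain is again removed, a loss in this assay is expected, though perhaps smaller than that step, as a methoxymethyl retains one hydrogen-bond acceptor; the expected step is a number 0.66 log units lower from compound 1 to compound 3 (beyond the scatter). Compound 3 is thus estimated at 5.2, within 4.6 to 5.8.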

Compound 3, logarithm of the reciprocal of the active concentration, log(1/C): 5.19
Compound 3: middle estimate off by 0.01 log units, on the high side, within the range that was stated.
By their numbers in this assay, from the lowest: compound 2; then compound 3; then compound 1.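

In this assay, methoxymethyl on this saturated chain carbon gives neither the highest nor the lowest value: there is a number 0.67 log units lower from compound 1 to compound 3 (beyond the scatter), yet also a number 0.45 log units higher from compound 2 to compound 3 (beyond the scatter). The position therefore gives graded values, not one uniform drop whenever the carbamate-bearing group leaves. Nothing measured here explains this order. From the compounds shown here alone, it remains open whether the carbamate itself or the chain that carries it accounts for the higher value of compound 1. Going by these compounds, how a hydroxyl or an amine at this place would compare also remains open.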